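Chain substituent at the saturated ring carbon: ethyl to phenyl

The source may hold more compounds than are shown below. What is called first, only, known or untested is meant among the compounds shown, and "the series" means these compounds.

Among the measured compounds shown here, compound 2 `CCCC1C(=O)N(C)c2cnc(Nc3ccc(S(N)(=O)=O)cc3)nc2N1C` gives 206 nM in an assay on Sf9 cells for inhibition of serine/threonine-protein kinase 4 (Homo sapiens), read by luminescence and ADP-Glo, with a stated time of 1 h, in the presence of a further agent that is not named here (on this read-out higher numbers stand for weaker inhibition and lower numbers for stronger inhibition), the lower of the two numbers so far, though the gap to compound 1 is within the scatter. Compound 1 `CC1C(=O)N(C)c2cnc(Nc3ccc(S(N)(=O)=O)cc3)nc2N1C` gives 313 nM, and the step of a 1.5-fold lower number from compound 1 to compound 2 (0.18 log units; within the scatter) stays inside the scatter. Compound 3 `CN1C(=O)C(Cc2ccccc2)N(C)c2nc(Nc3ccc(S(N)(=O)=O)cc3)ncc21` differs from compound 2 by phenyl in place of ethyl on a saturated chain carbon bound to a saturated ring carbon. For the measured compounds named here, the only step touching this chain carbon is a 1.5-fold lower number from compound 1 to compound 2 (0.18 log units; within the scatter), so no movement beyond the scatter is expected for compound 3 in this assay. Compound 3 is expected at 180 nM, range 60 nM to 550 nM. The expected step is a 1.1-fold lower number from compound 2 to compound 3 (0.06 log units; within the scatter).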

Compound 3, half-maximal inhibitory concentration: > 10000 nM
Compound 3: no number, only a limit (the forecaster's own chance of this, stated with the estimate: 3%); at least 55-fold (1.74 log units) between middle value and limit.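

In this assay compound 3 stands at > 10000 nM as a limit and not a number. The chain carbon bound to the saturated ring carbon does not accept every substituent: hydrogen and ethyl there stay within the scatter of each other (a 1.5-fold lower number from compound 1 to compound 2 (0.18 log units; within the scatter)), while phenyl gives an at least 48-fold higher number from compound 2 to compound 3 (1.68 log units; beyond the scatter) and an at least 31-fold higher number from compound 1 to compound 3 (1.50 log units; beyond the scatter) on the same read-out. Both new steps end at a limit, so their full size stays unknown: the limit of > 10000 nM in this assay, at which 1 of the 3 values shown sits.

As far as these compounds go, it remains open whether the drop follows the aromatic ring itself or the size of the substituent. A cyclohexyl group or a butyl chain at this carbon would separate the two.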